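This account rests on a few compounds, and the source may have more. Where it says the series, first, only, none or still open, it means among the compounds named here.

Measured so far in an ADME assay on MT4 cells (Homo sapiens) for cytotoxicity, read by MTT assay, with a stated time of 5 days; a higher number here means that more compound is tolerated, a lower number that less compound is tolerated:
compound 1, `CCNC(c1ccnc(Nc2ccc(C#N)cc2)n1)c1ccccc1Cl`: 39400 nM
compound 2, `CC(C)NC(c1ccnc(Nc2ccc(C#N)cc2)n1)c1ccccc1Cl`: 35500 nM
compound 3, `N#C/C=C/c1ccc(C(NO)c2ccnc(Nc3ccc(C#N)cc3)n2)cc1`: 161000 nM

Compound 1 gives the second highest of the three numbers. Compound 2 is nearest to it: the step of a 1.1-fold lower number from compound 1 to compound 2 (0.05 log units; within the scatter) lies within the scatter, so the two are read as the same. Going by the values given here, compound 3 stands furthest away, with a number higher than that of compound 1 beyond the scatter; no single-change step links compound 3 to compound 1, so its value is only noted.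

The next compound is compound 4, `CCNC(c1ccc(C#N)cc1)c1ccnc(Nc2ccc(C#N)cc2)n1`. It differs from compound 1 in one place: 4-cyanophenyl in place of 2-chlorophenyl on a saturated chain carbon bound to an amine nitrogen and an aromatic carbon. Among the compounds with values here, none of the measured steps bears on this change. Within the data shown here, the only measured step, from compound 1 to compound 2, concerns the group on the amine nitrogen, not the aryl group on the saturated chain carbon. Compound 3 carries a different aryl group at that carbon but also a different amine, so its higher number cannot be assigned to the aryl change alone. The expectation for this assay therefore rests on little: a step of a 1.3-fold higher number from compound 1 to compound 4 (0.10 log units; within the scatter) near zero, with the higher value of compound 3 leaving room for a move upward rather than downward. For compound 4 the estimate is 50000 nM, expected to fall between 20000 nM and 150000 nM.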

Compound 4, half-maximal cytotoxic concentration: 158000 nM
For compound 4 the middle estimate is 3.2-fold (0.50 log units) below the measured one, and the stated range ends below it.
By their numbers in this assay, from the lowest: compounds 2 and 1 (each within the scatter of the next); then compounds 4 and 3 (each within the scatter of the next).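

In this assay, going by these compounds alone, 4-cyanophenyl in place of 2-chlorophenyl on a saturated chain carbon bound to an amine nitrogen and an aromatic carbon gives a 4.0-fold higher number from compound 1 to compound 4 (0.60 log units; beyond the scatter) and is the first single change to move the number beyond the scatter. Within the data shown here, the only earlier step, a 1.1-fold lower number from compound 1 to compound 2 (0.05 log units; within the scatter), lay at the group on the amine nitrogen and stayed within the scatter, so the aryl group at this carbon is the one place so far where a single change shifts how much compound is tolerated. Nothing measured here accounts for the size of this step.

The compounds shown leave open whether the step belongs to the loss of the chlorine or to the entry of the nitrile, and an unsubstituted phenyl at this carbon would separate the two. Also open, going by these compounds, is whether the group on the amine nitrogen still makes no difference with 4-cyanophenyl in place, for which a longer chain or a hydroxyethyl group on that nitrogen would be a direct test.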